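Swapping Methoxy Patterns on a Shared Core

The compounds below may be only part of what the source reports. "The series", "measured", "known", "first", "only" and "open" are said of these compounds alone.

Four compounds share one core and were tested in a functional assay on A549 cells (Homo sapiens) for antiproliferative activity, read by MTT assay, with a stated time of 24 h; a lower number here means a stronger inhibitor, a higher number a weaker inhibitor. Compound 1 `COc1ccc(C2CC(c3ccc(Cl)cc3)=NN2c2ccc(-c3ccccc3)nn2)c(OC)c1` reaches only a limit of the assay, > 100000 nM. Compound 2 `COc1cc(C2CC(c3ccc(Cl)cc3)=NN2c2ccc(-c3ccccc3)nn2)cc(OC)c1OC` gives 83300 nM, and compound 3 `COc1ccc(C2=NN(c3ccc(-c4ccccc4)nn3)C(c3ccc(OC)cc3OC)C2)cc1` gives 100000 nM. Compound 2 differs from compound 1 by 3,4,5-trimethoxyphenyl in place of 2,4-dimethoxyphenyl on a saturated ring carbon, a change that made an at least 1.2-fold lower number from compound 1 to compound 2 (0.07 log units; that floor lies within the scatter). Compound 3 differs from compound 1 by methoxy in place of chloro on an aromatic carbon, giving a number no higher from compound 1 to compound 3 (the limit leaves the size open). Compound 4 `COc1ccc(C2=NN(c3ccc(-c4ccccc4)nn3)C(c3cc(OC)c(OC)c(OC)c3)C2)cc1`, not yet measured, differs from compound 3 by 3,4,5-trimethoxyphenyl in place of 2,4-dimethoxyphenyl on a saturated ring carbon. This is the same kind of change as between compound 1 and compound 2, but here the place lies two ring bonds from the ring atom that bears a 4-methoxyphenyl group rather than a 4-chlorophenyl group. The expected step, resting on the earlier step of an at least 1.2-fold lower number from compound 1 to compound 2 (0.07 log units; that floor lies within the scatter) that lay within the scatter, is a 1.3-fold lower number from compound 3 to compound 4 (0.10 log units; within the scatter). Compound 4 is therefore estimated at 80000 nM.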

Compound 4, half-maximal inhibitory concentration: > 100000 nM
Compound 4: a limit, no number; the forecaster's own chance of this, stated with the estimate: 30%; at least 1.2-fold (0.09 log units) between middle value and limit.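

The result for compound 4 is a limit of the assay, not a number, so the swap to 3,4,5-trimethoxyphenyl gives a number no lower from compound 3 to compound 4 (the limit leaves the size open), and its size cannot be read on the core of compound 3. Methoxy in place of chloro gives an at least 1.2-fold higher number from compound 2 to compound 4 (0.07 log units; that floor lies within the scatter), yet this does not show that the change acts alike on both cores. Whether either change carries over from one core to the other in this assay stays unsettled, because some of the values rest on a limit: the limit of > 100000 nM in this assay, at which 2 of the 4 values shown sit.

Among the compounds shown, only methoxy and chloro groups vary on the phenyl rings.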